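The source may hold more compounds than are shown below. What is called first, only, known or untested is meant among the compounds shown, and "the series" means these compounds.

The measured compounds, with their values in a functional assay on HepG2 cells (Homo sapiens) for antiproliferative activity, read by MTT assay, with a stated time of 72 h; a higher number here means a weaker inhibitor, a lower number a stronger inhibitor:
compound 1, `c1ccc(COc2ccccc2Nc2ncnc3cc4c(cc23)OCCOCCO4)cc1`: > 100000 nM.
compound 2, `c1ccc(COc2ccccc2Nc2ncnc3cc4c(cc23)OCCOCCOCCO4)cc1`: 37300 nM.
compound 3, `FC(F)(F)c1ccc(COc2ccccc2Nc2ncnc3cc4c(cc23)OCCOCCOCCO4)cc1`: > 100000 nM.

The value of compound 1 in this assay is a limit of the assay, not a number. For compound 3 the value is likewise a limit. Compound 2 and compound 3 differ in one place: trifluoromethyl in place of hydrogen on an aromatic carbon. That change gives an at least 2.6-fold higher number from compound 2 to compound 3 (0.42 log units; beyond the scatter). Compound 4, `FC(F)(F)c1ccc(COc2ccccc2Nc2ncnc3cc4c(cc23)OCCOCCO4)cc1`, has not yet been measured; it comes from compound 1 by the same change, (trifluoromethyl in place of hydrogen on an aromatic carbon). How the core of compound 1 differs from the core of compound 2 is not broken down here. Because compound 1 already sits at the limit of > 100000 nM in this assay, at which 2 of the 3 values shown sit, the same change is expected to leave compound 4 at that limit as well, so the expected step that the limit leaves unreadable from compound 1 to compound 4 cannot be read off as a real number. The estimate for compound 4 in this assay is 200000 nM.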

Compound 4, half-maximal inhibitory concentration: > 100000 nM
Compound 4: a limit, no number; the forecaster's own chance of this, stated with the estimate: 90%; the middle value is on the limit's open side.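

The values of compound 1 and compound 4 are both limits of the assay, not numbers, so no step between them can be read: the limit of > 100000 nM in this assay, at which 3 of the 4 values shown sit.

As far as these compounds go, whether trifluoromethyl changes anything on the core of compound 1 in this assay stays open.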